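A few compounds are considered here, and "the series" means these few. Any claim that something is new, unique, unknown or untested is made for them only; others in the source may bear on it.

Measured compounds:
Compound 1 `Cc1noc(C)c1COC1CC(=O)Nc2c1c(C)nn2-c1ncnc2nc[nH]c12` — 5 nM in a functional assay on HEK293 cells for agonist activity at G-protein coupled receptor 39 (Homo sapiens), read by scintillation proximity assay and inositol phosphate accumulation, with a stated time of 75 min, in the presence of a further agent that is not named here; on this read-out lower numbers stand for an effect already at smaller amounts and higher numbers for an effect only at larger amounts of compound
Compound 3 `CCC(C(=O)NC1CC(=O)Nc2c1c(C)nn2-c1ncnc2nc[nH]c12)c1ccccc1` — 5 nM in this assay
Compound 2 `CC(C)(C)c1cc(C(=O)N/N=C/c2ccc(O)cc2O)[nH]n1` — 240 nM in this assay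

Compound 1 stands level with compound 3 at the digits recorded, the two together the lowest of the three numbers in this assay; compound 2 sits at a far higher number, a gap beyond the scatter. Among the compounds with values here, no step between two measured compounds that differ in one place is available, so the path from compound 1 to compound 4 `Cc1nn(-c2ncnc3nc[nH]c23)c2c1C(OCc1ccccc1Cl)CC(=O)N2` rests on the structural change alone. 2-chlorophenyl in place of 3,5-dimethyl-1,2-oxazol-4-yl on a saturated chain carbon bound to an oxygen on a saturated carbon Compound 1 at 5 nM and compound 3 at 5 nM carry quite different groups at this side of the shared core and still agree in this assay, which hints that variation there is tolerated, though two compounds are too few to call it a rule. The author expects the step from compound 1 to compound 4 in this assay to be small, likely within the scatter, perhaps a slight rise: a 2.0-fold higher number from compound 1 to compound 4 (0.30 log units; within the scatter). Compound 4 is therefore estimated at about 10 nM, within the range 2 nM to 50 nM.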

Compound 4, half-maximal effective concentration: 2 nM
Beside the measured number, compound 4's estimate is 5.0-fold (0.70 log units) above it; measured number inside the range.
By their numbers in this assay, from the lowest: compound 4; then compounds 1 and 3 (each within the scatter of the next); then compound 2.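

In this assay, the exchange of 3,5-dimethyl-1,2-oxazol-4-yl for 2-chlorophenyl on a saturated chain carbon bound to an oxygen on a saturated carbon gives a 2.5-fold lower number from compound 1 to compound 4 (0.40 log units; beyond the scatter). Within the data shown here, this is the first comparison at this position between compounds that differ in one place, and it turns the earlier hint of tolerance into a measured result: a ring of carbon only, with no hydrogen-bond acceptors, does not lose ground to the five-membered ring with its two. No measurement here accounts for the modest gain.

The compounds shown do not separate the contribution of the chlorine from that of the six-membered ring that carries it. On these data alone, how a plain phenyl or a pyridine ring would fare at this position remains open.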